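This account rests on a few compounds, and the source may have more. Where it says the series, first, only, none or still open, it means among the compounds named here.

Measured compounds: compound 1 `COc1cc(NC(=O)Nc2cc(Nc3ccc(C(C)(C)C)cc3)ncn2)cc(OC)c1` gives 17.5% in a functional assay on NCI-H520 cells (Homo sapiens) for inhibition, read by MTT assay, with a stated time of 48 h, tested at 10 uM; a lower number here means less inhibition, a higher number more inhibition at the concentration tested (going by the name of the read-out); compound 2 `Cc1ccc(Nc2cc(NC(=O)Nc3c(Cl)cccc3Cl)ncn2)cc1F` gives 33.5%; compound 3 `COc1ccc(F)cc1Nc1cc(NC(=O)Nc2c(Cl)cccc2Cl)ncn1` gives 38.1%.

Compound 1 stands lowest of the three, and its gaps to compound 2 and to compound 3 lie beyond the usual scatter. Compound 4 `CCc1cccc(Nc2cc(NC(=O)Nc3cc(OC)cc(OC)c3)ncn2)c1` is not yet measured. It differs from compound 1 by 3-ethylphenyl in place of 4-(tert-butyl)phenyl on a nitrogen on an aromatic ring. For the measured compounds named here, the one measured step that bears on this, a swap of the aryl group on the same nitrogen, was a number 4.6 percentage points higher from compound 2 to compound 3 (within the scatter). From that, no step beyond the scatter is expected in this assay. Compound 4 is therefore expected to stay close to compound 1, with a step of a number 2.5 percentage points higher from compound 1 to compound 4 (within the scatter). The estimate for compound 4 is 20%, ranging from 8% to 34%.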

Compound 4, a percentage reported as inhibition, at one concentration (the size of the read-out at that concentration, not a potency): 23%
Beside the measured number, compound 4's estimate is 3 percentage points below it, within the range that was stated.
By their numbers in this assay, from the lowest: compounds 1 and 4 (each within the scatter of the next); then compounds 2 and 3 (each within the scatter of the next).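

In this assay, a number 5.5 percentage points higher from compound 1 to compound 4 (within the scatter) came with 3-ethylphenyl in place of 4-(tert-butyl)phenyl on the nitrogen. This is the first such swap shown with the dimethoxyphenyl urea of compound 1, and it stays within the scatter, as the swap in the dichlorophenyl pair did. No measurement here bears on the reason for this result.

The compounds shown leave open whether an aryl group carrying an amine or a carboxylic acid at this nitrogen would give a step beyond the scatter. They also leave open whether a morpholine ring in place of the aryl group would do so.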